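Swapping Halogens on the Carbonyl-Bound Ring

A few compounds are considered here, and "the series" means these few. Any claim that something is new, unique, unknown or untested is made for them only; others in the source may bear on it.

Compound 1 `Cc1nc(N(C)C(=O)NC(=O)c2c(F)cccc2F)sc1C(=O)N/N=C/c1ccccc1F` in a functional assay on HepG2 cells (Homo sapiens) for inhibition, read by MTT assay, with a stated time of 72 h (on this read-out lower numbers stand for stronger inhibition and higher numbers for weaker inhibition), gives > 100 ug/mL, which is a limit of the assay and not a number.
Compound 2 `Cc1nc(N(C)C(=O)NC(=O)c2c(F)cccc2F)sc1C(=O)N/N=C/c1ccc(Cl)cc1Cl` in this assay gives 70 ug/mL.
Compound 3 `Cc1nc(N(C)C(=O)NC(=O)c2ccc(Cl)cc2Cl)sc1C(=O)N/N=C/c1ccc(C(F)(F)F)cc1` in this assay gives > 100 ug/mL, again a limit rather than a measured number.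

Compound 3 thus stands at the upper edge of what this assay reports, and it is not alone there, since two of the three values sit at the same limit (the limit of > 100 ug/mL in this assay, at which 2 of the 3 values shown sit). Compound 4 `Cc1nc(N(C)C(=O)NC(=O)c2c(F)cccc2F)sc1C(=O)N/N=C/c1ccc(C(F)(F)F)cc1` differs from compound 3 in one place: 2,6-difluorophenyl in place of 2,4-dichlorophenyl on a carbonyl carbon.

Among the compounds with values here, only one measured step exists, an at least 1.4-fold lower number from compound 1 to compound 2 (0.15 log units; that floor lies within the scatter), and it changes the ring on the carbon double-bonded to nitrogen, not the ring on the carbonyl carbon, so no measured step covers the change from compound 3 to compound 4 directly. Compounds 1 and 2 already carry the entering 2,6-difluorophenyl, and between them one value is a limit and the other a number close to it, which suggests this part of the molecule leaves the read-out weak either way. The step from compound 3 to compound 4 is therefore expected to be a step that the limit leaves unreadable from compound 3 to compound 4, not beyond the scatter. Compound 4 is expected to give about 120 ug/mL, with a range from 60 ug/mL to 300 ug/mL, and a limit again seems the more likely outcome.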

Compound 4, half-maximal inhibitory concentration: > 100 ug/mL
Compound 4 gave a limit, no number; the forecaster's own chance of this, stated with the estimate: 65%; the middle value does not contradict the limit.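

Compound 4 also sits at a limit of the assay rather than at a number, so 2,6-difluorophenyl in place of 2,4-dichlorophenyl on a carbonyl carbon produces no measurable value while 4-(trifluoromethyl)phenyl stays on the carbon with a double bond to nitrogen: the limit of > 100 ug/mL in this assay, at which 3 of the 4 values shown sit. The steps that link compound 4 to compound 3 and to compound 1 join limit to limit, and their size cannot be read. Within the data shown here, the one readable step, 4-(trifluoromethyl)phenyl in place of 2,4-dichlorophenyl on a carbon with a double bond to nitrogen, is an at least 1.4-fold higher number from compound 2 to compound 4 (0.15 log units; that floor lies within the scatter), so the data do not set compound 2 apart from compound 4.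

As far as these compounds go, whether the ring on the carbonyl carbon matters at all in this assay stays open, as any difference between 2,4-dichlorophenyl and 2,6-difluorophenyl is hidden when both compounds of the pair sit at the limit. Also open, from the compounds shown here alone, is what a different kind of group would do on the ring on the carbon with a double bond to nitrogen, such as an amine, a carboxylic acid or a longer chain.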